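The source may report more compounds than this note shows. Statements on the series, on what has been measured and on what is new or still open speak of the compounds shown alone.

Compound 1 `O=C(O)/C=C/c1ccncc1-c1ccc2cc[nH]c2c1` carries the carboxy group at the end of the chain. In a functional assay on A549 cells (Homo sapiens) for inhibition, read by sulforhodamine B assay, with a stated time of 72 h (a lower number here means a stronger inhibitor of growth, a higher number a weaker inhibitor of growth), compound 1 gives > 10000 nM, which is a limit of the assay and not a number. Compound 2 `NC(=O)/C=C/c1ccncc1-c1ccc2ccccc2c1` has amino on the carbonyl carbon and another core. In this assay compound 2 gives > 10000 nM, again a limit. Compound 3 `COC1CN(C(=O)/C=C/c2ccncc2-c2ccc3ccccc3c2)C1` has 3-methoxyazetidin-1-yl in place of amino on that carbonyl carbon. In this assay compound 3 gives > 10000 nM, also a limit. The step that the two limits leave unreadable from compound 2 to compound 3 therefore cannot be read, and the limit of > 10000 nM in this assay, at which 3 of the 3 values shown sit, is the whole of what the series has shown so far.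

Compound 4 `CNC(=O)/C=C/c1ccncc1-c1ccc2cc[nH]c2c1` differs from compound 1 by methylamino in place of hydroxy on a carbonyl carbon. Going by the values given here, no measured step bears directly on this change; the only step of the same place, on a carbonyl carbon, is the unreadable one above. Nothing in the numbers points to a gain, so compound 4 is expected to stay at the limit in this assay, with the step that the limit leaves unreadable from compound 1 to compound 4 expected to be none beyond the scatter. The estimate for compound 4 is 15000 nM, within 5000 nM to 50000 nM.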

Compound 4, concentration for 50% growth inhibition: 7840 nM
Beside the measured number, compound 4's estimate is 1.9-fold (0.28 log units) above it, within the range that was stated.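

Methylamino in place of hydroxy on a carbonyl carbon gives the first number of the series that is not a limit: in this assay compound 4 gives 7840 nM. The step is an at least 1.2-fold lower number from compound 1 to compound 4 (0.10 log units; that floor lies within the scatter), so the true size of the change stays unresolved and it cannot be called a gain, though growth inhibition at this position is now within reach of measurement. The series as a whole still stands mostly at the edge of the assay: the limit of > 10000 nM in this assay, at which 3 of the 4 values shown sit.

Going by these compounds, whether ethylamino or dimethylamino on that carbonyl carbon would carry the number further from the limit remains open. Also open, on these data alone, is whether methylamino on the core of compound 2 would give a number that can be read at all.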